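Removing the Phenoxycarbonyl Cap from Compound 3

The source may report more compounds than this note shows. Statements on the series, on what has been measured and on what is new or still open speak of the compounds shown alone.

The study concerns a set of compounds sharing the core of compound 1 `COc1ccc(S(=O)(=O)N2CCc3cccc(NCc4ccccc4)c32)cc1`. In a functional assay on MKN-45 cells (Homo sapiens) for cytotoxicity (on this read-out higher numbers stand for weaker inhibition and lower numbers for stronger inhibition), compound 1 gives only a limit of the assay, > 10000 nM. Compound 2 `COc1ccc(S(=O)(=O)N2CCc3cccc(NC(=O)N(C)c4ccccc4)c32)cc1` likewise returns only a limit in this assay, > 10000 nM. Compound 3 `COc1ccc(S(=O)(=O)N2CCc3cccc(NC(=O)Oc4ccccc4)c32)cc1` too shows only a limit in this assay, > 10000 nM. As a consequence the steps among them cannot be read: a step that the two limits leave unreadable from compound 1 to compound 2, a step that the two limits leave unreadable from compound 1 to compound 3 and a step that the two limits leave unreadable from compound 2 to compound 3 are all left undetermined by the two limits, a point made plain by the limit of > 10000 nM in this assay, at which 3 of the 3 values shown sit. Compound 3 therefore stands at the same limit as the two other measured compounds, and no number places it apart from them.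

Compound 4 `COc1ccc(S(=O)(=O)N2CCc3cccc(N)c32)cc1` differs from compound 3 in one place: hydrogen in place of phenoxycarbonyl on a nitrogen on an aromatic ring. Going by the values given here, none of the measured steps gives a readable size for a change at this nitrogen; every one of them is hidden by the limit. Among the compounds with values here, the only guidance is that every measured compound sits at the limit, so the expected step from compound 3 to compound 4 is a step that the limit leaves unreadable from compound 3 to compound 4, with no direction the data can support. The estimate for compound 4 in this assay is 20000 nM, within a range from 5000 nM to 100000 nM, and most likely a limit again.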

Compound 4, half-maximal inhibitory concentration: 1200 nM
The estimate for compound 4 lay 17-fold (1.22 log units) above the measured number; the whole stated range lies above it.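

In this assay, going by these compounds alone, the bare amino group is the first form of this nitrogen to give a readable number rather than a limit, and removing the phenoxycarbonyl cap gives an at least 8.3-fold lower number from compound 3 to compound 4 (0.92 log units; beyond the scatter). Replacing the other two groups on this nitrogen with hydrogen points the same way, with an at least 8.3-fold lower number from compound 2 to compound 4 (0.92 log units; beyond the scatter) for the methyl(phenyl)carbamoyl group and an at least 8.3-fold lower number from compound 1 to compound 4 (0.92 log units; beyond the scatter) for the benzyl group. The change at this nitrogen therefore matters in this assay, although these steps give only a minimum size and the steps among the three capped compounds remain unreadable, and the picture stays one-sided: the limit of > 10000 nM in this assay, at which 3 of the 4 values shown sit.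

The compounds shown leave open whether the readable value depends on the hydrogen itself or would survive a small group on the amino nitrogen, such as a methyl or an acetyl group. They also leave open whether a group without an aromatic ring, such as a longer alkyl chain or a chain ending in a carboxylic acid, would stay near compound 4 or fall back to the limit shared by the three capped compounds.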